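The source may hold more compounds than are shown below. What is called first, only, known or untested is meant among the compounds shown, and "the series" means these compounds.

Measured in a functional assay on HCT-116 cells (Homo sapiens) for antiproliferative activity, read by WST assay, with a stated time of 72 h; a higher number here means a weaker inhibitor of growth, a lower number a stronger inhibitor of growth:

- Compound 1 `O=C(NO)c1cnc(N2C[C@@H]3[C@H](C2)[C@H]3NS(=O)(=O)c2cccs2)nc1`: > 10000 nM, a limit of the assay
- Compound 2 `O=C(NO)c1cnc(N2C[C@@H]3[C@H](C2)[C@H]3NC(=O)c2cccs2)nc1`: 3600 nM
- Compound 3 `O=C(NO)c1cnc(N2C[C@@H]3[C@H](C2)[C@H]3NC(=O)c2ccccc2)nc1`: 5100 nM

Compound 3 stands level with compound 2 within the scatter, as a 1.4-fold higher number from compound 2 to compound 3 (0.15 log units; within the scatter) shows, so swapping the aromatic ring on the carbonyl carbon changed little. Compound 4 `O=C(NO)c1cnc(N2C[C@@H]3[C@H](C2)[C@H]3NCc2ccccc2)nc1` carries benzyl in place of benzoyl on an amine nitrogen. Among the compounds with values here, no measured step removes the carbonyl outright, so any forecast is an extrapolation. The nearest evidence is a change of the same link on the same nitrogen, where an at least 2.7-fold lower number from compound 1 to compound 2 (0.44 log units; beyond the scatter) is at least modest and lies beyond the scatter. The matching an at least 1.9-fold lower number from compound 1 to compound 3 (0.29 log units; that floor lies within the scatter) has a floor within the scatter. These steps show that the link matters in this assay, and they favour a lower number, though only weakly. The expected change is a 5.1-fold lower number from compound 3 to compound 4 (0.71 log units; beyond the scatter), a moderate step towards stronger growth inhibition. For compound 4 the estimated value is 1000 nM, with an expected range of 150 nM to 5000 nM.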

Compound 4, concentration for 50% growth inhibition: 120 nM
Estimate against measurement, compound 4: 8.3-fold (0.92 log units) above; the measured number lies below the stated range.
By their numbers in this assay, from the lowest: compound 4; then compounds 2 and 3 (each within the scatter of the next). At a limit, above all of these: compound 1.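

In this assay, removing the carbonyl from the link on the amine nitrogen gives a 43-fold lower number from compound 3 to compound 4 (1.63 log units; beyond the scatter), a large step at a position where changing the aromatic ring on that carbonyl had shown no change beyond the scatter. The large gain also appears against the other amide, with a 30-fold lower number from compound 2 to compound 4 (1.48 log units; beyond the scatter), so compound 4 separates clearly from both carbonyl-linked compounds. Against the sulfonyl-linked compound the step is an at least 83-fold lower number from compound 1 to compound 4 (1.92 log units; beyond the scatter), which is only a floor, as the value of compound 1 is a limit of the assay: the limit of > 10000 nM in this assay, at which 1 of the 4 values shown sits.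

The compounds shown leave open whether the aromatic ring is needed at all, or whether a plain alkyl group such as methyl on this nitrogen would serve as well. As far as these compounds go, it also remains open how a longer chain such as phenethyl, or a thiophen-2-ylmethyl group, would compare with benzyl.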